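From Methyl to Sec-Butyl in an Antiproliferative Series

The source may report more compounds than this note shows. Statements on the series, on what has been measured and on what is new or still open speak of the compounds shown alone.

Of the compounds shown here, three have been measured in a functional assay on HeLa cells (Homo sapiens) for antiproliferative activity, read by MTT assay, with a stated time of 48 h; a lower number here means a stronger inhibitor, a higher number a weaker inhibitor. Compound 1 `CC[C@@H](C)[C@H](NC(=O)c1ccc(Oc2nc3ccccc3nc2C)cc1)C(=O)OC` reaches only the limit of the assay, at > 50000 nM. Compound 2 `COC(=O)[C@H](CC(C)C)NC(=O)c1ccc(Oc2nc3ccc(Cl)cc3nc2C)cc1` gives 37600 nM, and compound 3 `CCCCCCCCCCCCNc1nc2ccccc2nc1Oc1ccc(C(=O)N[C@@H](C)C(=O)OC)cc1` gives 28500 nM. These last two values lie within the scatter of each other, so compound 3 stands level with compound 2 and cannot be separated from it.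

Compound 4 `CCCCCCCCCCCCNc1nc2ccccc2nc1Oc1ccc(C(=O)N[C@H](C(=O)OC)[C@H](C)CC)cc1` departs from compound 3 in one place, with sec-butyl in place of methyl on a saturated chain carbon bound to an amide-type nitrogen and a carbonyl carbon.

Among the measured compounds shown here, no pair of measured compounds isolates this change in this assay. The expectation therefore starts from compound 3 at 28500 nM, and no shift beyond the scatter is anticipated, in either direction. The expected step is a 1.1-fold lower number from compound 3 to compound 4 (0.06 log units; within the scatter). Compound 4 is estimated at 25000 nM, with an expected range of 9000 nM to 50000 nM.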

Compound 4, half-maximal inhibitory concentration: 40300 nM
Compound 4: the middle estimate sits 1.6-fold (0.21 log units) below what was measured; the range from low to high includes it.
By their numbers in this assay, from the lowest: compounds 3, 2 and 4 (each within the scatter of the next). At a limit, above all of these: compound 1.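

In this assay, the first step read at this position, sec-butyl in place of methyl on a saturated chain carbon bound to an amide-type nitrogen and a carbonyl carbon, gives a 1.4-fold higher number from compound 3 to compound 4 (0.15 log units; within the scatter), so the two compounds cannot be told apart. In this one pair, the position takes the larger sec-butyl group, with its defined stereocentre, without a shift beyond the scatter. Among the compounds shown here, compound 1 stays a limit and not a number, and it enters no step: the limit of > 50000 nM in this assay, at which 1 of the 4 values shown sits.

Going by these compounds, whether a benzyl group, an aminobutyl chain or a carboxymethyl group at this place would move the number beyond the scatter remains open. On these data alone, it is also open whether sec-butyl would behave the same way if the rest of compound 3 were changed.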